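Methyl for Fluoro on the Thiourea Aryl Ring

A few compounds are considered here, and "the series" means these few. Any claim that something is new, unique, unknown or untested is made for them only; others in the source may bear on it.

Two close relatives of a shared core have been tested in a functional assay on HL-60 cells (Homo sapiens) for antiproliferative activity, with a stated time of 24 h; a lower number here means a stronger inhibitor, a higher number a weaker inhibitor. Compound 1 `Cc1ccccc1NC(=S)N1CCc2c(sc(NC(=O)c3ccccc3Cl)c2C(N)=O)C1` gives 22600 nM. Compound 2 `NC(=O)c1c(NC(=O)c2ccccc2Br)sc2c1CCN(C(=S)Nc1ccccc1F)C2` reaches only the limit of this assay, > 50000 nM, so no number is known for it; that limit is where one of the two values sits (the limit of > 50000 nM in this assay, at which 1 of the 2 values shown sits). Compound 3 `Cc1ccccc1NC(=S)N1CCc2c(sc(NC(=O)c3ccccc3Br)c2C(N)=O)C1` has not yet been measured. It differs from compound 2 in one place: methyl in place of fluoro on an aromatic carbon, ortho to a large group. Within the data shown here, since compound 2 is known only as a limit, the step to compound 3 cannot be sized from measured pairs, and no measured step between any two compounds is available. The author expects compound 3 to be measurable rather than lost at the limit, and estimates the step from compound 2 to compound 3 in this assay at an at least 1.6-fold lower number from compound 2 to compound 3 (0.22 log units; that floor lies within the scatter). For compound 3 the estimate is 30000 nM, with a range from 12000 nM to 70000 nM.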

Compound 3, half-maximal inhibitory concentration: > 50000 nM
Compound 3 was reported as a limit; the forecaster's own chance of this, stated with the estimate: 35%; middle value at least 1.6-fold (0.22 log units) from the limit.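

With the bromo group held, methyl in place of fluoro on the thiourea aryl ring does not bring a measurable value into range, so this change alone does not restore activity in this assay. The step between these two compounds cannot be read, since both ends are limits of the assay: the limit of > 50000 nM in this assay, at which 2 of the 3 values shown sit.

Among these compounds, the result does give the first readable step: with the 2-methylphenyl group held, bromo in place of chloro on an aromatic carbon gives an at least 2.2-fold higher number from compound 1 to compound 3 (0.34 log units; beyond the scatter). The halogen on the other aryl ring therefore matters in this assay, which compounds 1 and 2 alone could not show, as they differ in two places.

Going by these compounds, whether the 2-fluorophenyl group would give a measurable value with chloro in place of bromo remains open. So does how a methoxy group or an amine in place of the methyl would read.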